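Carbamoyl ring enlargement: notes on compound 3

The compounds below may be only part of what the source reports. "The series", "measured", "known", "first", "only" and "open" are said of these compounds alone.

Compound 1 `N#Cc1cnc(NCc2ccccc2C(F)(F)F)cc1N[C@H]1C[C@@H](C(N)=O)C1` and compound 2 `N#Cc1cnc(NCc2ccccc2C(F)(F)F)cc1N[C@H]1C[C@H](C(N)=O)C1` share all atoms and bonds and differ only in configuration as drawn. Going by the values given here, in an ADME assay on S9 fraction from liver (Homo sapiens) for metabolic stability, with a stated time of 1 h (a higher number here means that more of the compound is left, a lower number that less of the compound is left), compound 1 gives 86% and compound 2 gives 68%; the step of a number 18 percentage points lower from compound 1 to compound 2 (beyond the scatter) is modest yet beyond the scatter, so compound 2 stands lowest of the two numbers so far, with compound 1 as its only neighbour. Compound 3 `N#Cc1cnc(NCc2ccccc2C(F)(F)F)cc1N[C@H]1CC[C@@H](C(N)=O)CC1` differs from compound 2 in one place: 4-carbamoylcyclohexyl in place of 3-carbamoylcyclobutyl on a nitrogen on an aromatic ring. Among the compounds with values here, no measured step concerns a change of ring size; the only step in hand, a number 18 percentage points lower from compound 1 to compound 2 (beyond the scatter), rests on configuration alone the fact that compounds 1 and 2 differ only in the configuration as drawn and does not carry over to this change. The expectation for this assay is therefore a step of no clear direction, a number 2 percentage points higher from compound 2 to compound 3 (within the scatter), kept close to compound 2. Compound 3 is estimated at 70%, with a range from 50% to 90%.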

Compound 3, percent of the compound remaining: 48%
The estimate for compound 3 lay 22 percentage points above the measured number; measured number outside the range, below it.
By their numbers in this assay, from the lowest: compound 3; then compound 2; then compound 1.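

In this assay, the place on a nitrogen on an aromatic ring responds to ring size as well as to configuration: 4-carbamoylcyclohexyl in place of 3-carbamoylcyclobutyl gives a number 20 percentage points lower from compound 2 to compound 3 (beyond the scatter), and a number 38 percentage points lower from compound 1 to compound 3 (beyond the scatter). Compound 3 therefore stands lowest of the three whichever cyclobutyl compound serves as the reference, and those two references form a pair of one particular kind: the fact that compounds 1 and 2 differ only in the configuration as drawn The step is modest from one reference and large from the other, so this ring change has no single size in the series.

The compounds shown leave open how the other configuration of 4-carbamoylcyclohexyl would stand, and where a 3-carbamoylcyclopentyl group would fall. Also open, going by these compounds, is whether a carboxylic acid in place of the carbamoyl group would change the order of the rings.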